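The compounds below may be only part of what the source reports. "The series", "measured", "known", "first", "only" and "open" are said of these compounds alone.

In a functional assay on Hep 3B2 cells (Homo sapiens) for inhibition, read by MTT assay, with a stated time of 72 h (on this read-out higher numbers stand for weaker inhibition and lower numbers for stronger inhibition), compound 3 `Nc1ncnc2c1c(-c1cnc3[nH]ccc3c1)nn2CCCCCCCCCC(=O)NO` gives 17200 nM. That cannot be told apart from compound 1 `CNC(=O)CCCCCCCn1nc(-c2cnc3[nH]ccc3c2)c2c(N)ncnc21`, which carries methylcarbamoyl on its chain and gives 16300 nM: the measured step is a 1.1-fold higher number from compound 1 to compound 3 (0.02 log units; within the scatter). With a shorter chain than compound 3 and the same hydroxycarbamoyl end, compound 2 `Nc1ncnc2c1c(-c1cnc3[nH]ccc3c1)nn2CCCCCCCCC(=O)NO` gives 8390 nM.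

Compound 4 `Nc1ncnc2c1c(-c1cnc3[nH]ccc3c1)nn2CCCCCCC(=O)NO` shortens the chain further, and its change from compound 3 is hydroxycarbamoyl in place of 3-(hydroxycarbamoyl)propyl on a saturated chain carbon, six bonds along the chain from an aromatic nitrogen. In words, hydroxycarbamoyl takes the place of 3-(hydroxycarbamoyl)propyl on a saturated chain carbon, six bonds along the chain from an aromatic nitrogen.

The most relevant evidence is a 2.1-fold higher number from compound 2 to compound 3 (0.31 log units; beyond the scatter), a modest change that only just clears the usual scatter. Read in reverse, it suggests that a shorter chain may bring a lower number. The other two steps, a 1.9-fold lower number from compound 1 to compound 2 (0.29 log units; within the scatter) and a 1.1-fold higher number from compound 1 to compound 3 (0.02 log units; within the scatter), compare end groups and say little about chain length. Within the data shown here, no measurement yet covers a chain as short as that of compound 4, so the trend rests on a single pair and may not continue.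

A small move toward stronger inhibition is therefore expected, with the estimated step being a 1.9-fold lower number from compound 3 to compound 4 (0.28 log units; within the scatter).

Compound 4 is estimated at 9000 nM, with an expected range of 3500 nM to 22000 nM.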

Compound 4, half-maximal inhibitory concentration: 26300 nM
The estimate for compound 4 lay 2.9-fold (0.47 log units) below the measured number; the whole stated range lies below it.
By their numbers in this assay, from the lowest: compounds 2, 1, 3 and 4 (each within the scatter of the next, the first and the last beyond it).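

In this assay, with a 1.5-fold higher number from compound 3 to compound 4 (0.18 log units; within the scatter) and a 1.6-fold higher number from compound 1 to compound 4 (0.21 log units; within the scatter), the shortest chain shown, with hydroxycarbamoyl on the saturated chain carbon six bonds along from an aromatic nitrogen, cannot be told apart from either the longest chain or the methylcarbamoyl end. The clearer result is a 3.1-fold higher number from compound 2 to compound 4 (0.50 log units; beyond the scatter), which, taken with a 2.1-fold higher number from compound 2 to compound 3 (0.31 log units; beyond the scatter), shows that among these three hydroxycarbamoyl chains the lowest number belongs to the middle length, so shortening the chain does not steadily lower the number and the earlier single pair could not have shown this turn. No accompanying measurement explains why the numbers fall into this shape.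

On these data alone, both steps away from compound 2 are modest and all the numbers are high, so it remains open whether this shallow dip marks a real preferred length or only a small wobble among weak compounds. As far as these compounds go, it is also open how a chain longer than that of compound 3, or a carboxylic acid or an amine at the chain end in place of hydroxycarbamoyl, would read on this scale.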